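The compounds below may be only part of what the source reports. "The series", "measured", "known", "first", "only" and "open" are said of these compounds alone.

The measured compounds and their values:

Compound 1, `O=C(Nc1nc2ccc(Cl)cc2s1)c1cn(-c2ccccc2)nc1-c1ccccc1`, in an ADME assay on HEK-293T cells (Homo sapiens) for cytotoxicity, read by MTT assay, with a stated time of 72 h; on this read-out higher numbers stand for weaker inhibition and lower numbers for stronger inhibition: 21300 nM
Compound 2, `COc1ccc2nc(NC(=O)c3cn(-c4ccccc4)nc3-c3ccccc3)sc2c1`: in this assay compound 2 reached only the limit of the assay, > 50000 nM.
Compound 3, `O=C(Nc1nc2ccccc2s1)c1cn(-c2ccccc2)nc1-c1ccc(Cl)cc1`, in this assay: 39600 nM

Compound 1 and compound 2 differ in one place, (methoxy in place of chloro on an aromatic carbon). The step between them in this assay is an at least 2.3-fold higher number from compound 1 to compound 2 (0.37 log units; beyond the scatter). Its upper end is open, since compound 2 sits at the limit of > 50000 nM in this assay, at which 1 of the 3 values shown sits. The two values of compound 1 and compound 3 lie within the scatter of each other, so no order is drawn between them. How the core of compound 1 and the core of compound 3 differ is not broken down here; the two hold the same atoms, joined differently.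

Compound 4, `COc1ccc(-c2nn(-c3ccccc3)cc2C(=O)Nc2nc3ccccc3s2)cc1`, has not yet been measured in this assay. It stands to compound 3 as compound 2 stands to compound 1: methoxy in place of chloro on an aromatic carbon. The change is of the same kind as that from compound 1 to compound 2, not the same: there the chloro sat on an aromatic carbon of a six-membered aromatic ring of carbon only, part of a fused or bridged system of two rings, meta to a fused ring and para to a fused ring; here it sits on a six-membered aromatic ring of carbon only, para to a large group. Beside the earlier step of an at least 2.3-fold higher number from compound 1 to compound 2 (0.37 log units; beyond the scatter), the step from compound 3 to compound 4 is expected to be a 1.6-fold higher number from compound 3 to compound 4 (0.22 log units; within the scatter), resting on that single precedent and on compound 3 standing at 39600 nM. Compound 4 is therefore estimated in this assay at 65000 nM, between 30000 nM and 150000 nM, with a fair chance that only a limit is reported.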

Compound 4, half-maximal inhibitory concentration: 18900 nM
The estimate for compound 4 lay 3.4-fold (0.54 log units) above the measured number; the measured number lies below the stated range.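

In this assay, methoxy in place of chloro, here read as 4-chlorophenyl to 4-methoxyphenyl, gave a 2.1-fold lower number from compound 3 to compound 4 (0.32 log units; beyond the scatter), so the change did not carry its direction over from one core to the other: the same change on two cores in this assay, an at least 2.3-fold higher number (0.37 log units; beyond the scatter) from compound 1 to compound 2 and a 2.1-fold lower number (0.32 log units; beyond the scatter) from compound 3 to compound 4, at least 4.9-fold (0.69 log units) apart, beyond the scatter of two such steps Compound 2 gives > 50000 nM, which is a limit of the assay and not a number. The two steps show that, in this series, the outcome of this change on one core cannot be taken over to another, but they do not show why they part, since the two pairs differ both in their cores and in the ring that carries the change, and one pair on each core cannot separate these.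

The compounds shown leave open whether a third core would follow either step, and whether the direction seen from compound 3 to compound 4 would hold for other groups on an aromatic carbon of a six-membered aromatic ring of carbon only, para to a large group. Fluoro, methyl, an amine or a carboxylic acid at that place could show whether methoxy and chloro are typical of what this position tolerates in this assay.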